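A few compounds are considered here, and "the series" means these few. Any claim that something is new, unique, unknown or untested is made for them only; others in the source may bear on it.

Series notes. Three compounds have numbers in an ADME assay on 184B5 cells (Homo sapiens) for cytotoxicity, read by MTT assay, with a stated time of 72 h; a higher number here means a weaker inhibitor of growth, a lower number a stronger inhibitor of growth. Compound 1 `[SeH]c1nc(NCc2ccccc2)c2cccnc2n1` gives 9130 nM. Compound 2 `Nc1nc([SeH])nc2ncccc12` gives 31100 nM. Compound 3 `CSc1nc(NCCCCc2ccccc2)c2ccccc2n1` gives 53600 nM, the highest of the three numbers; against compound 2 the gap is within the scatter, so no order between those two can be read, while against compound 1 the gap lies beyond the scatter, compound 1 holding the lower number.

The next step goes from compound 3 to compound 4 `CSc1nc(NCCCCCO)c2ccccc2n1`. The change is hydroxymethyl in place of phenyl on a saturated chain carbon, four bonds along the chain from a nitrogen on an aromatic ring. Among the compounds with values here, no measured pair in this set shows a change of this kind, so nothing in the numbers indicates its size or direction; the working expectation is a step that does not clearly exceed the scatter, if anything toward a higher number. Compound 4 is therefore expected at 65000 nM, with a range from 22000 nM to 190000 nM, which means an expected step of a 1.2-fold higher number from compound 3 to compound 4 (0.08 log units; within the scatter).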

Compound 4, concentration for total growth inhibition: > 100000 nM
Compound 4 was reported as a limit; the forecaster's own chance of this, stated with the estimate: 20%; middle value at least 1.5-fold (0.18 log units) away from the limit.
By their numbers in this assay, from the lowest: compound 1; then compounds 2 and 3 (each within the scatter of the next). At a limit, above all of these: compound 4.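

In this assay, within the data shown here, phenyl replaced by hydroxymethyl on a saturated chain carbon, four bonds along the chain from a nitrogen on an aromatic ring, gives the first readable step: an at least 1.8-fold higher number from compound 3 to compound 4 (0.27 log units; that floor lies within the scatter). The value of compound 4, > 100000 nM, is a limit of the assay and not a number. The step therefore shows a direction and a floor only, with its true size open upward: the limit of > 100000 nM in this assay, at which 1 of the 4 values shown sits.

From the compounds shown here alone, whether an amine or a carboxylic acid in place of the hydroxymethyl would give a number that can be read in this assay remains open. Also open, going by these compounds, is whether the same change would move the number in the same direction on the core of compound 1.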